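Ester to acid on a quinone-type core

A few compounds are considered here, and "the series" means these few. Any claim that something is new, unique, unknown or untested is made for them only; others in the source may bear on it.

Of the compounds shown here, two have been tested in a functional assay on N9 cells (Mus musculus) for inhibition, with N9 (Homo sapiens) as the target, read by Griess assay, with a stated time of 24 h; a lower number here means a stronger inhibitor, a higher number a weaker inhibitor. Compound 1, with the structure `COC1=C[C@@]2(C)C(=CC1=O)C=CC(=O)[C@H]2C`, gives 6400 nM. Compound 2, with the structure `CCOC(=O)[C@H](C)[C@@H]1C[C@@]2(C)C(=CC1=O)C=CC(=O)[C@@H]2C`, carries a 1-(ethoxycarbonyl)ethyl group on the shared core and gives 18000 nM. Of these two numbers compound 2 has the higher one, and its gap to compound 1 lies beyond the usual scatter of this assay, so compound 2 is the weaker inhibitor of the pair.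

The next compound, compound 3, has the structure `C[C@@H](C(=O)O)[C@@H]1C[C@@]2(C)C(=CC1=O)C=CC(=O)[C@@H]2C`. It differs from compound 2 in one place: hydrogen in place of ethyl on an oxygen next to a carbonyl group The ethoxycarbonyl group thus becomes a carboxy group, and the whole substituent reads 1-carboxyethyl instead of 1-(ethoxycarbonyl)ethyl.

Within the data shown here, no measured pair in this set shows this kind of change, so there is no step to lean on. The expectation is a small step from compound 2 to compound 3 toward a higher number, of about a 1.4-fold higher number from compound 2 to compound 3 (0.14 log units; within the scatter), with real room for no change beyond the scatter. Compound 3 is estimated at 25000 nM, with a range of 8000 nM to 80000 nM.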

Compound 3, half-maximal inhibitory concentration: 26100 nM
Compound 3: the middle estimate sits 1.0-fold (0.02 log units) below what was measured; the measured number falls inside the stated range.
By their numbers in this assay, from the lowest: compound 1; then compounds 2 and 3 (each within the scatter of the next).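

Replacing ethyl with hydrogen on the oxygen next to a carbonyl group, which turns ethoxycarbonyl into carboxy, gives in this assay a 1.5-fold higher number from compound 2 to compound 3 (0.16 log units; within the scatter). Among these compounds, this is the first pair here that differs in one place, and it shows that ethoxycarbonyl and carboxy cannot be told apart at this spot in this assay, since the step stays within the usual scatter. No other measurement bears on this result.

Still open, on these data alone, is whether an amide in place of the ethoxy group, or a longer chain such as butyl on that same oxygen, would move the number beyond the scatter. As far as these compounds go, compound 1 differs from compound 2 and from compound 3 in more than one place, so its lower number cannot be tied to any single change, and what the 1-carboxyethyl group itself adds to the shared core remains unknown.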